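A side-chain swap from compound 1 to compound 4

A few compounds are considered here, and "the series" means these few. Any claim that something is new, unique, unknown or untested is made for them only; others in the source may bear on it.

Compound 1 `COc1ccc(/C=C\c2cc(OC)c(OC)c(OC)c2)cc1OCc1ccc(CN2CCCC[C@@H]2C(=O)O)cc1`: > 10000 nM
Compound 2 `COc1ccc(/C=C\c2cc(OC)c(OC)c(OC)c2)cc1OCc1ccc(CNCCO)cc1`: 6600 nM
Compound 3 `COc1ccc(/C=C\c2cc(OC)c(OC)c(OC)c2)cc1OCc1ccc(CN2CC[C@H](C(=O)O)C2)cc1`: 7000 nM

All three compounds were tested in a functional assay on B16-F10 cells (Mus musculus) for antiproliferative activity, read by CCK-8 assay, with a stated time of 48 h; a higher number here means a weaker inhibitor, a lower number a stronger inhibitor. Compound 1 gives > 10000 nM, which is a limit and not a number. Its place on the scale is the limit of > 10000 nM in this assay, at which 1 of the 3 values shown sits.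

Compound 4 `COc1ccc(/C=C\c2cc(OC)c(OC)c(OC)c2)cc1OCc1ccc(CNCCN(C)C)cc1` has (2-(dimethylamino)ethyl)amino in place of 2-carboxypiperidin-1-yl on a saturated chain carbon bound to an aromatic carbon.

Two measured steps replace the same group. The first is an at least 1.5-fold lower number from compound 1 to compound 2 (0.18 log units; that floor lies within the scatter), and the second is an at least 1.4-fold lower number from compound 1 to compound 3 (0.15 log units; that floor lies within the scatter). On these data alone, both are only floors, so the true size of each step remains unknown. The two replacements end level with each other, as a 1.1-fold higher number from compound 2 to compound 3 (0.03 log units; within the scatter) shows. Compound 2, which also has an open chain, is the nearest guide at 6600 nM. A measurable value in that region is therefore expected, with a modest fall from the limit. The expected step is an at least 1.8-fold lower number from compound 1 to compound 4 (0.25 log units; that floor lies within the scatter). For compound 4 the estimate is 5500 nM, with an expected range of 2000 nM to 10000 nM.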

Compound 4, half-maximal inhibitory concentration: > 10000 nM
Compound 4 ended at the assay's limit; the forecaster's own chance of this, stated with the estimate: 15%; at least 1.8-fold (0.25 log units) between middle value and limit.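

In this assay compound 4 gives a limit and not a number, so an open chain on this saturated chain carbon does not by itself yield a measurable value: the limit of > 10000 nM in this assay, at which 2 of the 4 values shown sit. Exchanging hydroxy for dimethylamino at the chain end gives an at least 1.5-fold higher number from compound 2 to compound 4 (0.18 log units; that floor lies within the scatter), and the ring-bearing comparison gives an at least 1.4-fold higher number from compound 3 to compound 4 (0.15 log units; that floor lies within the scatter), so these floors hint at a loss without establishing one. The step between compound 1 and compound 4 cannot be read, as both ends are limits.

The compounds shown leave open whether the true values of compound 1 and compound 4 differ at all, and whether the chain end or the second amine nitrogen governs the result. A longer chain ending in hydroxy, or a morpholine ring at the chain end, could help separate these possibilities.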